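Swapping the amide substituent on a shared core

The source may report more compounds than this note shows. Statements on the series, on what has been measured and on what is new or still open speak of the compounds shown alone.

Three compounds share one core and differ only in the group attached to a carbonyl carbon. Compound 1 `CCN(CC)CCNC(=O)c1ccc(C(CC)(CC)c2ccc(OCCC(O)(CC)CC)c(C)c2)n1CC` gives 3350 nM in a functional assay on PC-3 cells (Homo sapiens) for antiproliferative activity, read by MTT assay, with a stated time of 48 h; on this read-out lower numbers stand for stronger inhibition and higher numbers for weaker inhibition. Compound 2 `C=CCN(C)C(=O)c1ccc(C(CC)(CC)c2ccc(OCCC(O)(CC)CC)c(C)c2)n1CC` gives 12800 nM in this assay, and compound 3 `CCC(C)C(NC(=O)c1ccc(C(CC)(CC)c2ccc(OCCC(O)(CC)CC)c(C)c2)n1CC)C(=O)O` gives 13800 nM. Among these three numbers compound 2 stands second highest; its nearest neighbour is compound 3, within the scatter, and its furthest is compound 1, which shows the step of a 3.8-fold higher number from compound 1 to compound 2 (0.58 log units; beyond the scatter) in reverse.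

Compound 4 `CCn1c(C(=O)NC(CO)CCO)ccc1C(CC)(CC)c1ccc(OCCC(O)(CC)CC)c(C)c1` has not yet been measured. Its difference from compound 2 is a group of 7 heavy atoms (4 carbon, 1 nitrogen, 2 oxygen; no ring) in place of a group of 5 heavy atoms (4 carbon, 1 nitrogen; no ring), on a carbonyl carbon.

Two measured steps change this same position. The step of a 3.8-fold higher number from compound 1 to compound 2 (0.58 log units; beyond the scatter) was beyond the scatter, while the step of a 1.1-fold higher number from compound 2 to compound 3 (0.03 log units; within the scatter) stayed within it, even though compound 3 also brings in hydrogen-bond donors and acceptors. On that basis the expected step of a 1.1-fold lower number from compound 2 to compound 4 (0.03 log units; within the scatter) is small, with no clear direction. Compound 4 is therefore estimated at 12000 nM, with a likely range from 5000 nM to 30000 nM.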

Compound 4, half-maximal inhibitory concentration: 8760 nM
The estimate for compound 4 lay 1.4-fold (0.14 log units) above the measured number; measured number inside the range.
By their numbers in this assay, from the lowest: compound 1; then compounds 4, 2 and 3 (each within the scatter of the next).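

In this assay, the step of a 1.5-fold lower number from compound 2 to compound 4 (0.16 log units; within the scatter) and the step of a 1.6-fold lower number from compound 3 to compound 4 (0.20 log units; within the scatter) both stay within the scatter, so 3-hydroxy-1-(hydroxymethyl)propyl on the amide-type nitrogen gives a result that cannot be told apart from those of the two groups it is compared with here. Allyl(methyl)amino carries no hydrogen-bond donors and the group entering in compound 4 carries several, yet this change in count comes with no step beyond the scatter. Compound 1 stays apart, with the step of a 2.6-fold higher number from compound 1 to compound 4 (0.42 log units; beyond the scatter) lying beyond the scatter, but nothing measured here bears on the cause of that gap.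

The compounds shown leave open whether the diethylamino group at the end of the chain in compound 1 is what sets it apart. A longer chain ending in the same amine, or a chain of the same length ending in a hydroxyl group, would speak to this.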